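Substituent changes on the aryl ring of the shared core

This account rests on a few compounds, and the source may have more. Where it says the series, first, only, none or still open, it means among the compounds named here.

Measured compounds:
compound 1 `Cc1ccc(C2C(C#N)=C(N)N(c3ccc(S(N)(=O)=O)cc3)C3=C2C(=O)CCC3)cc1` — 30%
compound 2 `N#CC1=C(N)N(c2ccc(S(N)(=O)=O)cc2)C2=C(C(=O)CCC2)C1c1ccc(O)cc1` — 95%
compound 3 `COc1ccc(C2C(C#N)=C(N)N(c3ccc(S(N)(=O)=O)cc3)C3=C2C(=O)CCC3)cc1` — 50%

In a functional assay on Ehrlich cells (Mus musculus) for antiproliferative activity, read by trypan blue exclusion, with a stated time of 2 h, tested at 25 ug/mL (on this read-out lower numbers stand for a weaker effect and higher numbers for a stronger effect at the one concentration tested), compound 3 gives 50%, the second highest of the three numbers, standing between compound 1 with 30% and compound 2 with 95%. Compound 4 `N#CC1=C(N)N(c2ccc(S(N)(=O)=O)cc2)C2=C(C(=O)CCC2)C1c1ccc([N+](=O)[O-])cc1` remains to be measured in this assay. It differs from compound 3 in one place: nitro in place of methoxy on an aromatic carbon.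

Three measured steps, all at the same aromatic carbon, are known: a number 20 percentage points higher from compound 1 to compound 3 (beyond the scatter), a number 65 percentage points higher from compound 1 to compound 2 (beyond the scatter) and a number 45 percentage points lower from compound 2 to compound 3 (beyond the scatter). Going by the values given here, they show that exchanges at this position can move the read-out in this assay by a large amount, but none of them involves a nitro group, so no step gives a direction for compound 4. The expectation is therefore a number near that of compound 3, with a wide range. The step of a number 5 percentage points higher from compound 3 to compound 4 (within the scatter) is expected to lie within the scatter. Compound 4 is estimated at 55% in this assay, between 20% and 90%.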

Compound 4, a percentage reported as activity, at one concentration (the size of the read-out at that concentration, not a potency): 80%
The estimate for compound 4 lay 25 percentage points below the measured number; the measured number falls inside the stated range.
By their numbers in this assay, from the lowest: compound 1; then compound 3; then compound 4; then compound 2.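

Nitro in place of methoxy gives a number 30 percentage points higher from compound 3 to compound 4 (beyond the scatter) in this assay and neither group counts a hydrogen-bond donor, so a rise of this kind at this aromatic carbon does not depend on the hydroxy of compound 2. Nitro in place of methyl gives a number 50 percentage points higher from compound 1 to compound 4 (beyond the scatter) while nitro in place of hydroxy gives a number 15 percentage points lower from compound 2 to compound 4 (beyond the scatter) and compound 2 therefore stays the highest of the four, with a second group now reaching the upper part of the range. No available data explain these differences.

On these data alone, whether an amine or a carboxylic acid at this carbon would fall near the hydroxy and nitro compounds or near the methyl and methoxy compounds stays open. Potency also stays open, since the read-out gives the size of the effect at one concentration.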